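A few compounds are considered here, and "the series" means these few. Any claim that something is new, unique, unknown or untested is made for them only; others in the source may bear on it.

Working notes on the series.

Compound 1 `CCn1ncc2c(F)cc(-c3ccc(C(CC)(CC)c4nnc[nH]4)c(=O)[nH]3)cc21` is measured in an assay on CHO cells for displacement of a labelled ligand from prostaglandin E2 receptor EP3 subtype (Homo sapiens), read by radioligand binding (on this read-out lower numbers stand for stronger inhibition and higher numbers for weaker inhibition), at 17 nM. Compound 2 `CC(C)C(Cc1nnc[nH]1)c1ccc(-c2ccc3cccc(F)c3c2)[nH]c1=O` gives 10 nM in the same assay, and compound 3 `CC(C)C(Nc1nccs1)c1ccc(-c2ccc3cccc(F)c3c2)[nH]c1=O` gives 9.4 nM; compound 1 therefore sits at the upper end of the three numbers, but its gaps to compound 2 and to compound 3 both fall inside the usual scatter, so the three values read as one level.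

Compound 4 `CCn1ncc2c(F)cc(-c3ccc(C(CC)(CC)c4ncn(C)n4)c(=O)[nH]3)cc21` is not yet measured. It differs from compound 1 in one place: 1-methyl-1H-1,2,4-triazol-3-yl in place of 4H-1,2,4-triazol-3-yl on a saturated chain carbon bound to an aromatic carbon and two saturated chain carbons. Within the data shown here, the only measured step among the known compounds is a 1.1-fold lower number from compound 2 to compound 3 (0.03 log units; within the scatter), which swaps one heterocyclic group for another on the chain carbon and leaves the number essentially unchanged. That step does not involve the methylation of a triazole ring, so it bears on the present change only loosely, as a sign that the group on the chain carbon tolerates variation. Among the measured compounds shown here, no measured step covers the loss of the ring hydrogen-bond donor itself.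

The expectation for compound 4 is a step of a 1.8-fold higher number from compound 1 to compound 4 (0.25 log units; within the scatter), a modest weakening that may still lie within the scatter. Compound 4 is estimated at 30 nM, with a range of 10 nM to 100 nM.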

Compound 4, inhibition constant: 39 nM
Beside the measured number, compound 4's estimate is 1.3-fold (0.11 log units) below it; the range from low to high includes it.
By their numbers in this assay, from the lowest: compounds 3, 2 and 1 (each within the scatter of the next); then compound 4.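

In this assay, among these compounds, the move from 4H-1,2,4-triazol-3-yl to 1-methyl-1H-1,2,4-triazol-3-yl gives a 2.3-fold higher number from compound 1 to compound 4 (0.36 log units; beyond the scatter) and is the first step to lie beyond the scatter. The group on a saturated chain carbon bound to an aromatic carbon and two saturated chain carbons is therefore not indifferent to this change, although the step is modest. Nothing available explains the shift in the number.

The entering group differs from the leaving group both by the added methyl and by having no hydrogen-bond donor, and the compounds shown do not separate the two. Also open, going by these compounds, is how a carboxylic acid or 1-ethyl-1H-1,2,4-triazol-3-yl at the same place would read, and whether the same methylation gives a similar step on the core of compound 2.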